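From an aromatic end to a hydroxyethyl end

A few compounds are considered here, and "the series" means these few. Any claim that something is new, unique, unknown or untested is made for them only; others in the source may bear on it.

compound 1 (`COc1ccc(C(=NNC(=O)NNC(=O)NCCCC(C)Nc2cc(OC)cc3cccnc23)c2ccc(OC)cc2)cc1`) - 12000 nM
compound 2 (`COc1cc(NC(C)CCCNC(=O)NNC(=O)Nc2ccc(Cl)c(C(F)(F)F)c2)c2ncccc2c1`) - 19000 nM
compound 3 (`CCOC(=O)NC(c1ccccc1)c1ccc(Cl)cc1`) - > 250000 nM (a limit)

In a functional assay on MOLT-4 cells (Homo sapiens) for inhibition, read by MTT assay, with a stated time of 4 days (on this read-out lower numbers stand for stronger inhibition and higher numbers for weaker inhibition), compound 2 gives 19000 nM and lies within the usual scatter of compound 1 at 12000 nM on this read-out. For compound 3 the entry > 250000 nM is a limit of the assay and not a number.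

Compound 4 (`COc1cc(NC(C)CCCNC(=O)NNC(=O)NCCO)c2ncccc2c1`) departs from compound 2 as follows: 2-hydroxyethyl in place of 4-chloro-3-(trifluoromethyl)phenyl on an amide-type nitrogen on an amide-type nitrogen. For the measured compounds named here, no measured pair shows such a change. Compound 1 at 12000 nM and compound 2 at 19000 nM both carry aromatic rings in that place, while compound 4 carries none, so a moderate step to a higher number in this assay is expected, beyond the scatter. The estimated step is a 2.4-fold higher number from compound 2 to compound 4 (0.37 log units; beyond the scatter) in this expectation. For compound 4 the expected value is 45000 nM with an estimated range from 14000 nM to 160000 nM as its span.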

Compound 4, half-maximal inhibitory concentration: > 250000 nM
Compound 4 was reported as a limit (the forecaster's own chance of this, stated with the estimate: 25%); at least 5.5-fold (0.74 log units) between middle value and limit.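

In this assay, for the compounds shown here, 2-hydroxyethyl in place of 4-chloro-3-(trifluoromethyl)phenyl on an amide-type nitrogen gives an at least 13-fold higher number from compound 2 to compound 4 (1.11 log units; beyond the scatter), the first step at this position, which no earlier pair could show. The entry for compound 4, > 250000 nM, is a limit of the assay and not a number. The step therefore has a lower bound but no measured upper end: the limit of > 250000 nM in this assay, at which 2 of the 4 values shown sit.

On these data alone, whether the ring itself or its chlorine and trifluoromethyl groups matter stays open. An unsubstituted phenyl or a longer alkyl chain at this nitrogen could help separate these.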